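A few compounds are considered here, and "the series" means these few. Any claim that something is new, unique, unknown or untested is made for them only; others in the source may bear on it.

Compound 1 `N=c1sc2cc(OC(F)(F)F)ccc2n1CC(N)=O`: 7 mg/kg
Compound 2 `CN(C)S(=O)(=O)CCn1c(=N)sc2cc(OC(F)(F)F)ccc21`: > 10 mg/kg, a limit rather than a number
Compound 3 `CCCSCCn1c(=N)sc2cc(OC(F)(F)F)ccc21`: 2.4 mg/kg

In a functional assay on the whole organism with Rattus norvegicus as the target (on this read-out lower numbers stand for an effect already at smaller amounts and higher numbers for an effect only at larger amounts of compound), compound 3 has the lower of the two actual numbers, while compound 2 has only a limit. Compound 4 `CS(=O)(=O)CCn1c(=N)sc2cc(OC(F)(F)F)ccc21` carries methylsulfonyl in place of propylsulfanyl, on a saturated chain carbon, two bonds along the chain from an aromatic nitrogen: methylsulfonyl in place of propylsulfanyl on a saturated chain carbon, two bonds along the chain from an aromatic nitrogen. The nearest guide is an at least 4.1-fold lower number from compound 2 to compound 3 (0.61 log units; beyond the scatter), where propylsulfanyl replaced dimethylsulfamoyl. The step of a 2.9-fold lower number from compound 1 to compound 3 (0.46 log units; beyond the scatter) also ends at propylsulfanyl. Read backwards, these steps lead to the expectation of a clearly higher number in this assay once propylsulfanyl is removed. The estimated step is a 3.8-fold higher number from compound 3 to compound 4 (0.57 log units; beyond the scatter). For compound 4 the estimate is 9 mg/kg, with an expected range from 3.5 mg/kg to 25 mg/kg.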

Compound 4, dose for half-maximal effect: 1.8 mg/kg
Compound 4: the middle estimate sits 5.0-fold (0.70 log units) above what was measured, and the stated range ends above it.
By their numbers in this assay, from the lowest: compounds 4 and 3 (each within the scatter of the next); then compound 1. At a limit, above all of these: compound 2.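

In this assay, a sulfonyl group at this place does not by itself cost effect: a 1.3-fold lower number from compound 3 to compound 4 (0.12 log units; within the scatter), and a 3.9-fold lower number from compound 1 to compound 4 (0.59 log units; beyond the scatter). What separates the two sulfonyl compounds is the group on the sulfur, since methyl in place of dimethylamino gives an at least 5.5-fold lower number from compound 2 to compound 4 (0.74 log units; beyond the scatter). That step is only a floor, as compound 2 has a limit rather than a number: the limit of > 10 mg/kg in this assay, at which 1 of the 4 values shown sits.

The compounds shown leave open how an amine or a carboxylic acid would read out at this place. On these data alone, it also remains open whether a longer chain carrying the methylsulfonyl would hold this level.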